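Amide series: aryl group in place of ethyl on carbonyl

This account rests on a few compounds, and the source may have more. Where it says the series, first, only, none or still open, it means among the compounds named here.

Compound 2 `CCC(=O)N(C)c1ccc2[nH]c(-c3n[nH]c4ccccc34)cc2n1` gives 6130 nM in a functional assay on HL-60 cells (Homo sapiens) for antiproliferative activity, read by MTT assay, with a stated time of 72 h (on this read-out higher numbers stand for weaker inhibition and lower numbers for stronger inhibition), the highest of the three numbers, though compound 1 `CC(=O)N(C)c1ccc2[nH]c(-c3n[nH]c4ccccc34)cc2n1` at 5110 nM lies within the scatter of it; compound 3 `CN(C(=O)c1ccc(F)cc1)c1ccc2[nH]c(-c3n[nH]c4ccccc34)cc2n1` gives 1210 nM. Compound 4 `COc1cccc(C(=O)N(C)c2ccc3[nH]c(-c4n[nH]c5ccccc45)cc3n2)c1` differs from compound 2 by 3-methoxyphenyl in place of ethyl on a carbonyl carbon. The step that bears most directly on this is a 5.1-fold lower number from compound 2 to compound 3 (0.70 log units; beyond the scatter), and a 4.2-fold lower number from compound 1 to compound 3 (0.63 log units; beyond the scatter) points the same way from the shorter chain, while a 1.2-fold higher number from compound 1 to compound 2 (0.08 log units; within the scatter) shows that chain length alone does not move the number. A step of comparable size toward a lower number is therefore expected, a 4.1-fold lower number from compound 2 to compound 4 (0.61 log units; beyond the scatter). The ring substituent of compound 4 differs from that of compound 3, so the range is kept wide. Compound 4 is estimated at 1500 nM, between 600 nM and 4000 nM.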

Compound 4, half-maximal inhibitory concentration: 1420 nM
Beside the measured number, compound 4's estimate is 1.1-fold (0.02 log units) above it; low and high end bracket the measured number.
By their numbers in this assay, from the lowest: compounds 3 and 4 (each within the scatter of the next); then compounds 1 and 2 (each within the scatter of the next).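

In this assay, a second aryl group on the carbonyl carbon gives the same kind of gain, with a 4.3-fold lower number from compound 2 to compound 4 (0.64 log units; beyond the scatter) and a 3.6-fold lower number from compound 1 to compound 4 (0.56 log units; beyond the scatter). The exchange of one aryl group for the other, a 1.2-fold higher number from compound 3 to compound 4 (0.07 log units; within the scatter), leaves 3-methoxyphenyl and 4-fluorophenyl not told apart, so in these two compounds the gain does not rest on one particular ring substituent. Nothing at hand accounts for these steps. Still open, from the compounds shown here alone, is whether unsubstituted phenyl would match these two aryl groups. Also open, going by these compounds, is whether a ring carrying an amine or a carboxylic acid would hold the number.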